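Shortening the Chain and Adding a Hydroxyl on Compound 2

This account rests on a few compounds, and the source may have more. Where it says the series, first, only, none or still open, it means among the compounds named here.

Of the compounds shown here, two have numbers so far. Compound 1 `CCc1cc(C(C)=O)c(O)cc1OCCCCCCC#N` and compound 2 `C=CCc1cc(C(C)=O)c(O)cc1OCCCCCCCCCCC#N` share a core and differ in more than one place, so only their two values are compared here. In an assay on isolated protein for binding affinity to leukotriene B4 receptor 1 (Homo sapiens), tested at 1 uM (on this read-out higher numbers stand for more inhibition at the one concentration tested (going by the name of the read-out) and lower numbers for less inhibition), compound 1 gives 73%, while compound 2 gives 14%, which is the lowest of the two numbers shown and stands a long way beneath compound 1, beyond the usual scatter.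

The next compound in line is compound 3 `C=CCc1cc(C(C)=O)c(O)cc1OCCCCCC(C)(C)O`, not yet measured in this assay. The change from compound 2 reads (1-hydroxy-1-methylethyl in place of 5-cyanopentyl on a saturated chain carbon, five bonds along the chain from an oxygen on an aromatic ring). The chain is thus cut short and ends in a group bearing a hydroxyl instead of running on to a nitrile.

Within the data shown here, no single-point step between measured compounds is known, so the size of this step in this assay is open. Compound 2 sits low, and the short-chained compound 1 sits high, so a rise is expected rather than a fall. The step from compound 2 to compound 3 is estimated at a number 21 percentage points higher from compound 2 to compound 3 (beyond the scatter). Compound 3 is expected to give about 35%, within a range of 8% to 65%.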

Compound 3, a percentage reported as inhibition, at one concentration (the size of the read-out at that concentration, not a potency): 60%
For compound 3 the middle estimate is 25 percentage points below the measured one, and the stated range covers the measured number.
By their numbers in this assay, from the lowest: compound 2; then compound 3; then compound 1.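

In this assay the exchange of 5-cyanopentyl for 1-hydroxy-1-methylethyl, on a saturated chain carbon, five bonds along the chain from an oxygen on an aromatic ring, amounts to a number 46 percentage points higher from compound 2 to compound 3 (beyond the scatter) and is a large step. Among these compounds, it is the first change in one place to be read, and it shows that this position is far from indifferent: what stands at the end of the chain can move the inhibition read at the one concentration tested by much more than the usual scatter. The entering group has 4 heavy atoms against 7 and brings a hydrogen-bond donor that the leaving group lacks, but no measurement bears on why the number rises.

As far as these compounds go, in this one step a shorter chain and a new end group arrive together, so the share of each remains unknown, and only a nitrile on the shorter chain or the same hydroxyl-bearing end group on the longer chain could separate them. From the compounds shown here alone, whether a carboxylic acid or an amine at the end of this chain would match the level at which compound 3 gives 60% also stays open.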